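A few compounds are considered here, and "the series" means these few. Any claim that something is new, unique, unknown or untested is made for them only; others in the source may bear on it.

Working notes on the series in a functional assay on A549 cells (Homo sapiens) for inhibition, read by MTT assay, with a stated time of 72 h; on this read-out lower numbers stand for stronger inhibition and higher numbers for weaker inhibition. Here compound 1 `O=C(Nc1ccccc1)C1CCN(C/C=C/c2ccccc2)CC1` gives 69700 nM, and compound 2 `CCCCc1ccc(NC(=O)C2CCN(C/C=C/c3ccccc3)CC2)cc1` gives 5910 nM. Compound 3 `COc1ccccc1NC(=O)C1CCN(C/C=C/c2ccccc2)CC1` gives > 100000 nM, which is a limit of the assay and not a number. Compound 4 `N#Cc1ccc(NC(=O)C2CCN(C/C=C/c3ccccc3)CC2)cc1` is not yet measured. The change is 4-cyanophenyl in place of 2-methoxyphenyl on an amide-type nitrogen. Among the compounds with values here, two measured steps bear on it. The methoxy step, an at least 1.4-fold higher number from compound 1 to compound 3 (0.15 log units; that floor lies within the scatter), has a floor within the scatter, while the butyl step, a 12-fold lower number from compound 1 to compound 2 (1.07 log units; beyond the scatter), is large. Within the data shown here, no measured step covers the nitrile itself. A moderate move to a lower number is therefore expected in this assay, an estimated at least 2.8-fold lower number from compound 3 to compound 4 (0.45 log units; beyond the scatter). The estimate for compound 4 is 35000 nM, with an expected range of 10000 nM to 100000 nM.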

Compound 4, half-maximal inhibitory concentration: 40200 nM
The estimate for compound 4 lay 1.1-fold (0.06 log units) below the measured number; the measured number falls inside the stated range.
By their numbers in this assay, from the lowest: compound 2; then compounds 4 and 1 (each within the scatter of the next). At a limit, above all of these: compound 3.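

In this assay, a cyano group put where compound 1 carries only hydrogen stays within the scatter, a 1.7-fold lower number from compound 1 to compound 4 (0.24 log units; within the scatter), while cyano in place of butyl gives a clear rise, a 6.8-fold higher number from compound 2 to compound 4 (0.83 log units; beyond the scatter). On the amide-type nitrogen, 4-cyanophenyl in place of 2-methoxyphenyl gives an at least 2.4-fold lower number from compound 3 to compound 4 (0.39 log units; beyond the scatter), so among the groups shown only butyl lowers the number beyond the scatter from that of compound 1. Compound 3 stands at a limit and not a number: the limit of > 100000 nM in this assay, at which 1 of the 4 values shown sits.

Open, going by these compounds, is whether a hexyl chain, an amine or a carboxylic acid in place of butyl would keep the number of compound 2 or lose it.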